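The source may report more compounds than this note shows. Statements on the series, on what has been measured and on what is new or still open speak of the compounds shown alone.

Measured compounds:
compound 1, `COc1c(NS(=O)(=O)C2CC2)cc(-c2ccc3nc(NC(=O)C4CC4)sc3c2)cc1C(N)=O`, 8220 nM in a functional assay on U-87MG ATCC cells (Homo sapiens) for antiproliferative activity, read by MTT assay, with a stated time of 72 h; a lower number here means a stronger inhibitor, a higher number a weaker inhibitor
compound 2, `COc1c(NS(=O)(=O)c2ccc(F)cc2)cc(-c2ccc3nc(NC(=O)C4CC4)nn3c2)cc1C(N)=O`, "not determined" (no result reported) in this assay

Within the data shown here, compound 1 is the only one of the pair with a number in this assay, so there is nothing it can be set against; on its own it is a weak inhibitor, with its value of 8220 nM. Compound 2 carries the same sulfonamide group that compound 3 will have, but on a different core, and since no result was reported for it, it offers no guide.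

Among the measured compounds shown here, compound 3, `COc1c(NS(=O)(=O)c2ccc(F)cc2)cc(-c2ccc3nc(NC(=O)C4CC4)sc3c2)cc1C(N)=O`, keeps the core of compound 1 and changes only one group: 4-fluorophenyl in place of cyclopropyl on a sulfonyl sulfur. For the measured compounds named here, no pair among the measured compounds shows the effect of such a change, so the expected step is uncertain. A step from compound 1 to compound 3 of about a 1.5-fold lower number from compound 1 to compound 3 (0.17 log units; within the scatter) is estimated, with either direction within reach. For compound 3 in this assay a value of about 5500 nM is expected, between 1500 nM and 20000 nM.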

Compound 3, half-maximal inhibitory concentration: 2870 nM
Beside the measured number, compound 3's estimate is 1.9-fold (0.28 log units) above it; the measured number falls inside the stated range.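

In this assay, putting 4-fluorophenyl in place of cyclopropyl on the sulfonyl sulfur gives a 2.9-fold lower number from compound 1 to compound 3 (0.46 log units; beyond the scatter). Among these compounds, this is the first sign that the group on this sulfur affects the read-out, and the shared core still gives a measurable effect when this group is a six-membered aromatic ring rather than a three-membered ring. The step is modest, however, and no independent measurement here explains why the swap has this effect.

The two compounds cannot show whether the step comes from the aromatic ring or from its fluorine; a plain phenyl group on the same sulfur would help separate the two. From the compounds shown here alone, how a small methyl group or a 4-methoxyphenyl group on this sulfur would compare also remains open.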